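The source may report more compounds than this note shows. Statements on the series, on what has been measured and on what is new or still open speak of the compounds shown alone.

Compound 2 `O=C(/C=C/c1ccc(N2CCCC2)cc1)c1ccc(O)cc1` is the starting point. In an assay on isolated protein for inhibition of DNA topoisomerase 1 (Homo sapiens), tested at 100 uM (a lower number here means a weaker effect, a higher number a stronger effect of the compound at the concentration tested), compound 2 gives 74.7%, which is the lowest of the three numbers recorded so far. Compound 3 `O=C(/C=C/c1ccc(N2CCCC2)cc1)c1ccc(F)cc1` differs from it in one place; in this assay compound 3 gives 90.6%, and the step of a number 15.9 percentage points higher from compound 2 to compound 3 (beyond the scatter) is beyond the scatter. Compound 1 `COc1cc(O)ccc1/C=C/C(=O)c1ccc(NC(C)=O)cc1` carries a different set of groups altogether, and in this assay compound 1 gives 100%, the highest of the three. Compound 4 `O=C(/C=C/c1ccc(N2CCCC2)cc1)c1ccc(O)cc1O` has not yet been measured. It differs from compound 2 by hydroxy in place of hydrogen on an aromatic carbon. Going by the values given here, none of the measured steps adds a hydroxy group to the shared core: the only step measured, a number 15.9 percentage points higher from compound 2 to compound 3 (beyond the scatter), swaps one group for another, so it gives no guide to the direction of this change. The expected step is therefore a number 2.3 percentage points higher from compound 2 to compound 4 (within the scatter), lying within the scatter. In this assay compound 4 is estimated at 77%, with a range from 55% to 96%.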

Compound 4, a percentage reported as inhibition, at one concentration (the size of the read-out at that concentration, not a potency): 87.1%
The estimate for compound 4 lay 10.1 percentage points below the measured number; low and high end bracket the measured number.
By their numbers in this assay, from the lowest: compound 2; then compounds 4, 3 and 1 (each within the scatter of the next, the first and the last beyond it).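

In this assay, going by these compounds alone, a hydroxy group placed on an aromatic carbon, ortho to a large group and meta to the hydroxy group already present, gives a number 12.4 percentage points higher from compound 2 to compound 4 (beyond the scatter) and so marks the first change at a carbon that held only hydrogen. The earlier step swapped a group already on this ring, whereas this one shows that the ring can take an added group here and the number still rises. No available evidence explains this rise.

From the compounds shown here alone, it remains open whether the rise belongs to the hydroxy group itself or whether an amine, a chlorine atom or a methyl group on the same carbon would give a similar number. Each number also comes from a single concentration, so it gives the size of the read-out and leaves the potency of these compounds unknown.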